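Removing One Methoxy Group: Cytotoxicity on OVCAR-5 Cells

A few compounds are considered here, and "the series" means these few. Any claim that something is new, unique, unknown or untested is made for them only; others in the source may bear on it.

Compound 1 `COc1cc(-c2cc(/C=C/C(=O)c3ccc(N)cc3)[nH]n2)cc(OC)c1OC`: 89%
Compound 2 `COc1ccc(-c2cc(/C=C/C(=O)c3ccc(N)cc3)[nH]n2)cc1OC`: 94%
Compound 3 `COc1cc(C(=O)/C=C/c2cc(-c3cc(OC)c(OC)c(OC)c3)n[nH]2)cc(OC)c1OC`: 89%

In a functional assay on OVCAR-5 cells (Homo sapiens) for cytotoxicity, read by sulforhodamine B assay, with a stated time of 48 h, tested at 1 uM (on this read-out higher numbers stand for a weaker effect at the one concentration tested and lower numbers for a stronger effect), compound 1 gives 89% and compound 2 gives 94%. The change between them, (hydrogen in place of methoxy on an aromatic carbon), produced a number 5 percentage points higher from compound 1 to compound 2 (within the scatter). Compound 3 gives 89% in this assay; how its core differs from that of compound 1 is not broken down here.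

Compound 4 `COc1ccc(-c2cc(/C=C/C(=O)c3cc(OC)c(OC)c(OC)c3)[nH]n2)cc1OC` is not yet measured. It differs from compound 3 by hydrogen in place of methoxy on an aromatic carbon, the same change as from compound 1 to compound 2, at a place described in the same words. Because a number 5 percentage points higher from compound 1 to compound 2 (within the scatter) stayed within the scatter, a step of similar size is expected, a number 3 percentage points higher from compound 3 to compound 4 (within the scatter). Compound 4 is therefore estimated at 92% in this assay, between 82% and 100%.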

Compound 4, a percentage reported as activity, at one concentration (the size of the read-out at that concentration, not a potency): 81%
Compound 4: the middle estimate sits 11 percentage points above what was measured, outside the stated range (below it).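

In this assay, hydrogen in place of methoxy on an aromatic carbon gave a number 8 percentage points lower from compound 3 to compound 4 (within the scatter). Set beside the earlier step, the two cores do not separate: the same change on two cores in this assay, a number 5 percentage points higher (within the scatter) from compound 1 to compound 2 and a number 8 percentage points lower (within the scatter) from compound 3 to compound 4, 13 percentage points apart, within the scatter of two such steps. In both cores the change stayed within the scatter at the one concentration tested, but this does not show that it acts identically on the two cores, and it gives no direction that could be carried to a further core.

The compounds shown leave open what a hydroxyl group or a fluorine atom would do in place of the methoxy group that leaves. They also leave open whether the two steps would stay within the scatter at another concentration.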